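Swapping 2-phenylethynyl for propyl in a cytotoxicity series

The source may hold more compounds than are shown below. What is called first, only, known or untested is meant among the compounds shown, and "the series" means these compounds.

- Compound 1 `O=c1[nH]c(=O)n([C@H]2C[C@H](O)[C@@H](CO)O2)cc1/C=N/O`: 15500 nM
- Compound 2 `CS(=O)(=O)Cc1cn([C@H]2C[C@H](O)[C@@H](CO)O2)c(=O)[nH]c1=O`: > 200000 nM (a limit, not a number)
- Compound 3 `O=c1[nH]c(=O)n([C@H]2C[C@H](O)[C@@H](CO)O2)cc1C#Cc1ccccc1`: > 200000 nM (a limit, not a number)

All three results come from an ADME assay on L1210/0 cells (Mus musculus) for cytotoxicity, with a stated time of 48 h; a higher number here means a weaker inhibitor, a lower number a stronger inhibitor. Compound 3 stands at > 200000 nM, which is a limit of the assay and not a measured number. It is not alone there, as the data show (the limit of > 200000 nM in this assay, at which 2 of the 3 values shown sit).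

Compound 4 `CCCc1cn([C@H]2C[C@H](O)[C@@H](CO)O2)c(=O)[nH]c1=O` has not been measured. It carries propyl in place of 2-phenylethynyl on an aromatic carbon.

Going by the values given here, two measured steps bear on this change, and both are large and beyond the scatter: an at least 12-fold higher number from compound 1 to compound 3 (1.11 log units; beyond the scatter) and an at least 12-fold higher number from compound 1 to compound 2 (1.11 log units; beyond the scatter). The remaining step adds nothing readable: a step that the two limits leave unreadable from compound 2 to compound 3. None of these steps tests propyl directly, so any expectation here is uncertain. Among the compounds with values here, compound 1 at 15500 nM is the only real number so far. Compound 4 is expected to sit much nearer the limit of the assay than that value, and possibly to reach it. The expected change in this assay is therefore modest: an at least 1.3-fold lower number from compound 3 to compound 4 (0.12 log units; that floor lies within the scatter). The estimate for compound 4 is 150000 nM, with an expected range from 50000 nM to 300000 nM.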

Compound 4, half-maximal inhibitory concentration: > 200000 nM
Compound 4: no number, only a limit; the forecaster's own chance of this, stated with the estimate: 55%; middle value at least 1.3-fold (0.12 log units) away from the limit.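

In this assay compound 4, which carries propyl, gives > 200000 nM, and this is a limit of the assay and not a number. A plain carbon chain with no ring and no triple bond on this aromatic carbon therefore ends at the same limit as 2-phenylethynyl and (methylsulfonyl)methyl, so three quite different groups at this position now share it: the limit of > 200000 nM in this assay, at which 3 of the 4 values shown sit. Going by these compounds alone, the one step that can be read is an at least 12-fold higher number from compound 1 to compound 4 (1.11 log units; beyond the scatter), and the two groups in it hold the same count of heavy atoms, so that count alone does not separate the one measured number from the limit.

The steps to compound 4 from compound 2 and from compound 3 cannot be read, as limits stand at both ends, and any order among these three stays unknown. Going by these compounds, it also stays open whether an amine, a carboxylic acid or a longer chain such as hexyl at this position would bring the number back towards that of compound 1 at 15500 nM, or whether that value stays unique to the group of compound 1.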